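A few compounds are considered here, and "the series" means these few. Any claim that something is new, unique, unknown or untested is made for them only; others in the source may bear on it.

Measured so far:
Compound 1 `C=C1C(=O)[C@@]23C(=O)OC[C@]4(C(=O)CCC(C)(C)[C@H]4C=O)[C@@H]2CC[C@@H]1[C@H]3OC(=O)c1ccccc1`: 1710 nM
Compound 2 `C=C1C(=O)[C@@]23C(=O)OC[C@]4(C(=O)CCC(C)(C)[C@H]4C=O)[C@@H]2CC[C@@H]1[C@H]3OC(=O)c1ccc([N+](=O)[O-])cc1`: 2680 nM

In a functional assay on CaEs17 cells (Homo sapiens) for cytotoxicity, read by MTT assay, with a stated time of 72 h (a higher number here means a weaker inhibitor, a lower number a stronger inhibitor), compound 2 gives 2680 nM, which lies within the scatter of compound 1 at 1710 nM, so the two cannot be told apart. Compound 3 `C=C1C(=O)[C@@]23C(=O)OC[C@]4(C(=O)CCC(C)(C)[C@H]4C=O)[C@@H]2CC[C@@H]1[C@H]3OC(=O)c1ccccc1Cl` keeps the core of compound 2 and differs in one place: 2-chlorophenyl in place of 4-nitrophenyl on a carbonyl carbon. In words, it has 2-chlorophenyl in place of 4-nitrophenyl on a carbonyl carbon. Among the compounds with values here, only one measured step bears on this change, nitro in place of hydrogen on an aromatic carbon, a 1.6-fold higher number from compound 1 to compound 2 (0.20 log units; within the scatter), and it stays within the scatter. Within the data shown here, no measured compound carries chlorine, so this support is limited and the range is kept wide. The expected change is a 1.3-fold lower number from compound 2 to compound 3 (0.13 log units; within the scatter), with no step beyond the scatter anticipated in either direction. For compound 3 the estimated value is 2000 nM, with an expected range of 900 nM to 4500 nM.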

Compound 3, half-maximal inhibitory concentration: 2010 nM
Compound 3: the middle estimate sits 1.0-fold (0.00 log units) below what was measured; the measured number falls inside the stated range.
By their numbers in this assay, from the lowest: compounds 1, 3 and 2 (each within the scatter of the next).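

In this assay, within the data shown here, chlorine appears on the aromatic ring for the first time, and neither of its two steps leaves the scatter: 2-chlorophenyl in place of 4-nitrophenyl on a carbonyl carbon gives a 1.3-fold lower number from compound 2 to compound 3 (0.12 log units; within the scatter), and adding chlorine to the unsubstituted ring gives a 1.2-fold higher number from compound 1 to compound 3 (0.07 log units; within the scatter). Compound 1, compound 2 and compound 3 therefore cannot be told apart, so neither the chloro nor the nitro substituent shown separates itself from the unsubstituted ring at this place. No independent measurement is available to explain this result.

Going by these compounds, whether an amine or a carboxylic acid on the ring, or a longer chain at this carbonyl carbon, would give a step beyond the scatter remains open. On these data alone, all three numbers come from this assay alone, so how these changes read in any other test also stays open.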